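Amide substituent variation in a weakly cytotoxic series

The source may report more compounds than this note shows. Statements on the series, on what has been measured and on what is new or still open speak of the compounds shown alone.

Compound 1 `NNC(=O)Cn1nc(N)c2c(C(F)(F)F)cc(-c3ccccc3)nc21` gives 53600 nM in a functional assay on A549 cells (Homo sapiens) for cytotoxicity, read by MTT assay, with a stated time of 24 h (a higher number here means a weaker inhibitor, a lower number a stronger inhibitor), a weak result. Compound 2 `Nc1nn(CC(=O)NC2CC2)c2nc(-c3ccccc3)cc(C(F)(F)F)c12` is reported in this assay as "not active" (no number reported), without a number, so it stands only as the weaker member of the pair. Compound 3 `CC(NC(=O)Cn1nc(N)c2c(C(F)(F)F)cc(-c3ccccc3)nc21)C(=O)O` is still to be measured in this assay. The change from compound 2 to compound 3 is 1-carboxyethyl in place of cyclopropyl on an amide-type nitrogen. For the measured compounds named here, no step between measured compounds is available, so in this assay no shift beyond the scatter is expected, with compound 3 staying at the weak end. Compound 3 is estimated at 80000 nM, range 30000 nM to 200000 nM, with a fair chance of no number at all, given that compound 1 gives 53600 nM and compound 2 gives none.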

Compound 3, half-maximal inhibitory concentration: 25600 nM
For compound 3 the middle estimate is 3.1-fold (0.49 log units) above the measured one; measured number outside the range, below it.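

In this assay the amide-type nitrogen carrying 1-carboxyethyl gives a number, with compound 3 at 25600 nM, while the step from the cyclopropyl of compound 2 cannot be read. With 1-carboxyethyl in place of amino, the series shows a 2.1-fold lower number from compound 1 to compound 3 (0.32 log units; beyond the scatter), so a number at this position is not limited to the amino member. No measured finding accounts for this change.

Open, from the compounds shown here alone, is whether the carboxylic acid of the 1-carboxyethyl group carries this result. A methyl ester or a plain ethyl group on the same nitrogen would separate the carboxylic acid from the chain.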